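The source may hold more compounds than are shown below. What is called first, only, known or untested is meant among the compounds shown, and "the series" means these compounds.

Compound 1 `COc1nc2ccc(Cl)cc2c(-c2ccccc2Cl)c1CCO` gives 141000 nM in an ADME assay on HepG2 2.2.15 cells (Homo sapiens) for cytotoxicity; a lower number here means that less compound is tolerated, a higher number that more compound is tolerated. Compound 2 `CC(C)(C)[Si](CCc1c(OCc2c(F)cccc2F)nc2ccc(Cl)cc2c1-c1ccccc1Cl)(c1ccccc1)c1ccccc1` is reported only as a limit in this assay, > 1860000 nM. Compound 3 `CC(C)(C)[Si](CCc1c(OCc2c(Cl)cccc2Cl)nc2ccc(Cl)cc2c1-c1ccccc1Cl)(c1ccccc1)c1ccccc1` is likewise reported only as a limit, > 1020000 nM.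

Compound 3 therefore stands at a limit in this assay (the limit of > 1020000 nM in this assay, at which 1 of the 3 values shown sits), and no number is known for it. Compound 2 also sits at a limit (the limit of > 1860000 nM in this assay, at which 1 of the 3 values shown sits). Within the data shown here, the single step between measured neighbours, a step that the two limits leave unreadable from compound 2 to compound 3, is unreadable, so no measured step bears on the change to compound 4 `CC(C)(C)[Si](CCc1c(N2CCCCC2)nc2ccc(Cl)cc2c1-c1ccccc1Cl)(c1ccccc1)c1ccccc1`, which is piperidin-1-yl in place of (2,6-dichlorobenzyl)oxy on an aromatic carbon. With nothing to read from, no step beyond the scatter is assumed, and compound 4 is expected to remain poorly cytotoxic, with an expected step of an at least 1.7-fold lower number from compound 3 to compound 4 (0.23 log units; that floor lies within the scatter). Compound 4 is estimated at 600000 nM, between 120000 nM and 2500000 nM.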

Compound 4, half-maximal cytotoxic concentration: > 968000 nM
Compound 4: no number, only a limit; the forecaster's own chance of this, stated with the estimate: 50%; at least 1.6-fold (0.20 log units) between middle value and limit.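

Compound 4, like compound 2 and compound 3, is reported in this assay only as a limit, so the steps among these three compounds cannot be read. The compounds shown leave open what actual number any of the three would give, and so whether piperidin-1-yl in place of (2,6-dichlorobenzyl)oxy changes it at all.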